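Isopropoxy variant of the fluorophenyl pyrazolopyridine series

This account rests on a few compounds, and the source may have more. Where it says the series, first, only, none or still open, it means among the compounds named here.

Measured so far:
Compound 1 `Fc1ccc(-c2nn3ccc(Cl)cc3c2-c2ccnc(NC3CCCC3)n2)cc1` gives, as a limit, > 40000 nM in an ADME assay on Vero cells (Chlorocebus sabaeus) for cytotoxicity; on this read-out higher numbers stand for lower toxicity in this test and lower numbers for higher toxicity in this test.
Compound 2 `COc1ccn2nc(-c3ccc(F)cc3)c(-c3ccnc(NC4CCCC4)n3)c2c1` gives, as a limit, > 36000 nM in this assay.
Compound 3 `COc1cc(NC2CCCC2)n2nc(-c3ccc(F)cc3)c(-c3ccnc(NC4CCCC4)n3)c2c1` gives, as a limit, > 40000 nM in this assay.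

Compound 3 stands at the limit of > 40000 nM in this assay, at which 2 of the 3 values shown sit, so only a limit is known for it and no number. The two measured steps are a step that the two limits leave unreadable from compound 1 to compound 2 and a step that the two limits leave unreadable from compound 2 to compound 3, and neither can be read in size, since both ends of each step are limits. Compound 4 `CC(C)Oc1cc(NC2CCCC2)n2nc(-c3ccc(F)cc3)c(-c3ccnc(NC4CCCC4)n3)c2c1` differs from compound 3 by isopropyl in place of methyl on an oxygen on an aromatic ring. Going by the values given here, nothing measured bears on an alkyl change at this oxygen; the only comparable evidence is that every value so far, at the limit of > 36000 nM in this assay, at which 1 of the 3 values shown sits, or (the limit of > 40000 nM in this assay, at which 2 of the 3 values shown sit), sits at a limit, so no step has yet been resolved in this assay. The expectation is therefore a step from compound 3 to compound 4 of a number no higher from compound 3 to compound 4 (the limit leaves the size open), nothing beyond the scatter. Compound 4 is thus estimated at 40000 nM, within 20000 nM to 80000 nM, most likely again reported only as a limit.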

Compound 4, half-maximal cytotoxic concentration: > 40000 nM
Compound 4: only a limit was reported; the forecaster's own chance of this, stated with the estimate: 80%; the middle value lies on the limit itself.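

Compound 3 and compound 4 are both reported only as limits in this assay, so the methoxy to isopropoxy change gives no readable step. The compounds shown leave open whether this change affects the read-out at all, and where any compound's actual value lies.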